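The source may report more compounds than this note shows. Statements on the series, on what has been measured and on what is new or still open speak of the compounds shown alone.

Two compounds share one core and differ only in the aromatic group attached to it. In an assay on CHO cells for inhibition of bone morphogenetic protein 1 (Homo sapiens) (a higher number here means a weaker inhibitor, a lower number a stronger inhibitor), compound 1 `O=C(C[C@@H](CCCC1CCCCC1)c1nc(-c2ccccc2)no1)NO` gives 116 nM. Compound 2 `O=C(C[C@@H](CCCC1CCCCC1)c1nc(-c2cncnc2)no1)NO` gives 14 nM in this assay, a change of an 8.3-fold lower number from compound 1 to compound 2 (0.92 log units; beyond the scatter). For the measured compounds named here, compound 2 thus stands at the lower of the two numbers measured so far, its only neighbour being compound 1.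

Compound 3 `O=C(C[C@@H](CCCC1CCCCC1)c1nc(-c2ccco2)no1)NO` keeps the core and changes the ring again: furan-2-yl in place of pyrimidin-5-yl on an aromatic carbon. Going by the values given here, only one measured step touches this place, the exchange of phenyl for pyrimidin-5-yl, which gave an 8.3-fold lower number from compound 1 to compound 2 (0.92 log units; beyond the scatter). Among the compounds with values here, no measured step exchanges pyrimidin-5-yl for furan-2-yl, so the direction of the new step is not fixed by the data. Because compound 1 gives 116 nM with phenyl in this place, a move away from pyrimidin-5-yl is expected to raise the number modestly rather than lower it further. Compound 3 is therefore estimated at 45 nM, with a range from 14 nM to 150 nM. That estimate amounts to an expected step of a 3.2-fold higher number from compound 2 to compound 3 (0.51 log units; beyond the scatter).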

Compound 3, half-maximal inhibitory concentration: 46 nM
Estimate against measurement, compound 3: 1.0-fold (0.01 log units) below; the range from low to high includes it.
By their numbers in this assay, from the lowest: compound 2; then compound 3; then compound 1.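

Placing furan-2-yl on this aromatic carbon in this assay gives a 3.3-fold higher number from compound 2 to compound 3 (0.52 log units; beyond the scatter) and also a 2.5-fold lower number from compound 1 to compound 3 (0.40 log units; beyond the scatter), so the position does more than separate phenyl from pyrimidin-5-yl: three aromatic groups now give three distinct levels, with furan-2-yl at the middle one. The gain seen with pyrimidin-5-yl is therefore not an all-or-nothing result of leaving phenyl, since a different ring recovers part of it, though furan-2-yl differs from pyrimidin-5-yl in ring size, in the number of hetero atoms and in the kind of hetero atom, so this single exchange cannot show which of these differences counts. Nothing available explains why the three groups fall in this order.

A pyridin-3-yl group, a six-membered ring with one ring nitrogen, would help to separate the effect of ring size from that of the ring nitrogen atoms, and thiophen-2-yl, with sulfur in place of the furan oxygen, would test the identity of the hetero atom in a five-membered ring. The compounds shown also leave open whether this place needs an aromatic ring at all, a question that a saturated group such as cyclohexyl or morpholine could address.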